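This account rests on a few compounds, and the source may have more. Where it says the series, first, only, none or still open, it means among the compounds named here.

Measured to date in a functional assay on SMMC-7721 cells (Homo sapiens) for inhibition, read by MTT assay, with a stated time of 72 h, tested at 25 uM; a lower number here means less inhibition, a higher number more inhibition at the concentration tested (going by the name of the read-out):

Compound 1 `Cc1nn(C)c(Oc2ccc(F)cc2)c1/C=N\OCc1c(Cl)c(-c2ccc(F)cc2)nn1C`: 80%
Compound 3 `Cc1ccc(Oc2c(/C=N\OCc3c(Cl)c(-c4ccc(F)cc4)nn3C)c(C)nn2C)cc1`: 80%
Compound 2 `CCc1nn(C)c(CO/N=C/c2c(C)nn(C)c2Oc2ccccc2F)c1Cl`: < 80%

Within the data shown here, compound 2 stands apart from the other two: its result in this assay is a limit of the assay, not a number, and it is the one value of the three that sits there (the limit of < 80% in this assay, at which 1 of the 3 values shown sits). Among the measured compounds shown here, compounds 1 and 3 share a second substituted core that compound 2 lacks, so no step is given between compound 2 and either of them.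

Compound 4 `CCc1nn(C)c(CO/N=C/c2c(C)nn(C)c2Oc2cccc(C)c2)c1Cl` differs from compound 2 in one place: 3-methylphenyl in place of 2-fluorophenyl on an oxygen on an aromatic ring. For the measured compounds named here, the only measured step of a related kind is no change at the digits printed from compound 1 to compound 3 (within the scatter), which exchanged fluoro for methyl on an aromatic carbon and left the reading unchanged within the scatter. Going by the values given here, that step, however, concerns the fluoro on the pendant aryl of compound 1 rather than the phenoxy ring, and the move from 2-fluorophenoxy to 3-methylphenoxy has no measured counterpart.

On this basis the step that the limit leaves unreadable from compound 2 to compound 4 is expected to be small or absent beyond the scatter, and compound 4 is expected to remain at or under the limit where compound 2 sits. Compound 4 is estimated at 45%, with a range from 10% to 79%, with a fair chance that only a limit is again reported.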

Compound 4, a percentage reported as inhibition, at one concentration (the size of the read-out at that concentration, not a potency): < 80%
Compound 4: a limit, no number; the forecaster's own chance of this, stated with the estimate: 0.65%; the middle value does not contradict the limit.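

In this assay, among these compounds, compound 2 and compound 4 both give a limit of the assay and not a number, so no step between them can be read. The compounds shown leave open whether 3-methylphenyl in place of 2-fluorophenyl on an oxygen on an aromatic ring changes inhibition at all, and by how much.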